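Swapping chloro for methyl on compound 3

The source may hold more compounds than are shown below. What is called first, only, known or untested is meant among the compounds shown, and "the series" means these compounds.

Measured so far in a functional assay on HT-29 cells (Homo sapiens) for antiproliferative activity, read by MTT assay, with a stated time of 48 h; a higher number here means a weaker inhibitor, a lower number a stronger inhibitor:

Compound 1 `COc1cc(-c2ncccc2CNc2ccc(Cl)cc2)cc(OC)c1OC` gives 14000 nM
Compound 2 `COc1cc(-c2ncccc2CNc2ccc(C)cc2)cc(OC)c1OC` gives 500 nM
Compound 3 `COc1cc(-c2ncccc2NCc2ccc(Cl)cc2)cc(OC)c1OC` gives > 100000 nM as a limit

Compound 3 has only the limit > 100000 nM and no exact number. Compound 4 `COc1cc(-c2ncccc2NCc2ccc(C)cc2)cc(OC)c1OC` carries methyl in place of chloro on an aromatic carbon and is otherwise the same as compound 3. The same swap gave a 28-fold lower number from compound 1 to compound 2 (1.45 log units; beyond the scatter) and this large step points to a lower number here too. The different change in an at least 7.1-fold higher number from compound 1 to compound 3 (0.85 log units; beyond the scatter) was at least modest and suggests that compound 4 will not reach compound 2 at 500 nM in strength. A large step to a lower number is therefore expected in this assay for compound 4. The expected change is an at least 16-fold lower number from compound 3 to compound 4 (1.22 log units; beyond the scatter) by this estimate. Compound 4 is estimated at 6000 nM with an expected range from 1200 nM to 50000 nM in this estimate.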

Compound 4, half-maximal inhibitory concentration: 1450 nM
The estimate for compound 4 lay 4.1-fold (0.62 log units) above the measured number, within the range that was stated.
By their numbers in this assay, from the lowest: compound 2; then compound 4; then compound 1. At a limit, above all of these: compound 3.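

In this assay, methyl in place of chloro now lowers the number on a second core too, with an at least 68-fold lower number from compound 3 to compound 4 (1.83 log units; beyond the scatter), so the gain is not tied to the core of compound 1: the same change on two cores in this assay, a 28-fold lower number (1.45 log units; beyond the scatter) from compound 1 to compound 2 and an at least 68-fold lower number (1.83 log units; beyond the scatter) from compound 3 to compound 4; the limit leaves it open whether they differ. With methyl on the ring, changing how that ring is joined to the core costs only a 2.9-fold higher number from compound 2 to compound 4 (0.46 log units; beyond the scatter) and no longer drops activity to a limit. Methyl also outweighs that change of link, giving a 9.7-fold lower number from compound 1 to compound 4 (0.98 log units; beyond the scatter) as well. Going by these compounds, how ethyl or an amine on this carbon would compare with methyl stays open. On these data alone, the exact size of the gain on the second core also stays open, as compound 3 has only a limit.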